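The source may report more compounds than this note shows. Statements on the series, on what has been measured and on what is new or still open speak of the compounds shown alone.

In a functional assay on HOS cells (Homo sapiens) for antiproliferative activity, with a stated time of 72 h (a higher number here means a weaker inhibitor, a lower number a stronger inhibitor), compound 1 `OC[C@H]1O[C@@H](n2cnc3c(NCc4ccc(F)cc4)ncnc32)[C@H](O)[C@@H]1O` gives 13200 nM. Compound 2 `OC[C@H]1O[C@@H](n2cnc3c(NCc4ccc(Cl)cc4)ncnc32)[C@H](O)[C@@H]1O` reads only as a limit, > 166000 nM. Compound 3 `OC[C@H]1O[C@@H](n2cnc3c(NCc4cccc(Br)c4)ncnc32)[C@H](O)[C@@H]1O` is also only a limit, > 166000 nM. The next change leads to compound 4 `OC[C@H]1O[C@@H](n2cnc3c(NCc4ccc(Br)cc4)ncnc32)[C@H](O)[C@@H]1O`: 4-bromophenyl in place of 3-bromophenyl on a saturated chain carbon bound to a nitrogen on an aromatic ring, with 4-bromophenyl in place of 3-bromophenyl. Two measured steps are large, an at least 12-fold higher number from compound 1 to compound 2 (1.09 log units; beyond the scatter) and an at least 12-fold higher number from compound 1 to compound 3 (1.09 log units; beyond the scatter), whereas a step that the two limits leave unreadable from compound 2 to compound 3. Compound 4 keeps the bromine of compound 3 and the 4-substituted phenyl of compound 2, and both of those halogen changes from compound 1 ended at the limit. No step beyond the scatter is therefore expected in this assay, and the expected step is an at least 1.1-fold lower number from compound 3 to compound 4 (0.04 log units; that floor lies within the scatter). For compound 4 the estimate is 150000 nM, with an expected range of 40000 nM to 300000 nM.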

Compound 4, half-maximal inhibitory concentration: > 166000 nM
Compound 4: only a limit was reported; the forecaster's own chance of this, stated with the estimate: 70%; middle value at least 1.1-fold (0.04 log units) from the limit.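

Compound 4 is only a limit, so 4-bromophenyl in place of 3-bromophenyl shows no readable effect of where the bromine sits. In this assay, 4-bromophenyl in place of 4-fluorophenyl gives an at least 12-fold higher number from compound 1 to compound 4 (1.09 log units; beyond the scatter), leaving compound 1 as the only one of the four with a measured value. The steps to compound 4 from compound 2 and compound 3 cannot be read because both ends of each are limits: the limit of > 166000 nM in this assay, at which 3 of the 4 values shown sit.

On these data alone, how far compound 2, compound 3 and compound 4 lie past that limit stays open. So does how a 3-fluorophenyl, or a phenyl carrying a methoxy group or an amine, would read in this assay.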